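Swapping the ring on the carbonyl of compound 2

A few compounds are considered here, and "the series" means these few. Any claim that something is new, unique, unknown or untested is made for them only; others in the source may bear on it.

Compound 1 `O=C(Nc1nnc(-c2ccc3c(c2)OCCO3)s1)c1ccccc1`: > 100 ug/mL (a limit)
Compound 2 `Nc1ccc(C(=O)Nc2nnc(-c3ccc4c(c3)OCCO4)s2)cc1`: > 100 ug/mL (a limit)

Both compounds were tested in a functional assay on HeLa cells (Homo sapiens) for antiproliferative activity, read by MTT assay, with a stated time of 48 h; a lower number here means that less compound is needed, a higher number that more compound is needed for the effect. Compound 2 gives > 100 ug/mL, which is a limit and not a number. Compound 2 therefore stands at the limit of > 100 ug/mL in this assay, at which 2 of the 2 values shown sit.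

Compound 3 `O=C(Nc1nnc(-c2ccc3c(c2)OCCO3)s1)c1ccc(Cl)nc1` has 6-chloropyridin-3-yl in place of 4-aminophenyl on a carbonyl carbon. For the measured compounds named here, the one measured step is a step that the two limits leave unreadable from compound 1 to compound 2, where amino replaces hydrogen on an aromatic carbon. It has no readable size, so it offers neither a size nor a direction to carry over to the new change. No clear shift is therefore expected in this assay, and the expected change is a number no higher from compound 2 to compound 3 (the limit leaves the size open). For compound 3 the estimated value is 100 ug/mL, with an expected range from 30 ug/mL to 300 ug/mL.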

Compound 3, half-maximal effective concentration: > 100 ug/mL
Compound 3 ended at the assay's limit; the forecaster's own chance of this, stated with the estimate: 65%; the middle value sits exactly at the limit.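

Compound 1, compound 2 and compound 3 all sit at the same limit of the assay, so no step among them can be read: the limit of > 100 ug/mL in this assay, at which 3 of the 3 values shown sit.

The compounds shown leave open how much of each is needed for the effect, and whether changing the group on the carbonyl carbon alters that amount at all.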